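mGluR5 modulators: a spiro carbocycle replaces fluoropiperidine

The compounds below may be only part of what the source reports. "The series", "measured", "known", "first", "only" and "open" are said of these compounds alone.

Measured compounds:
compound 1, `O=C([C@H]1CC2CCC1C2)N1CC(c2nc(-c3cccc(F)c3)no2)C1`: 72 nM
compound 2, `O=C(N1CCC(F)CC1)N1CC(c2nc(-c3cccc(Cl)c3)no2)C1`: 990 nM

In an assay on HEK293 cells for positive allosteric modulation of metabotropic glutamate receptor 5 (Homo sapiens), read by FLIPR (a higher number here means that more compound is needed for the effect, a lower number that less compound is needed), compound 1 gives 72 nM, while compound 2 gives 990 nM. Within the data shown here, compound 2 thus stands at the higher of the two numbers, and its gap to compound 1 lies beyond the scatter; since no step between them is computed, only the two values themselves can be compared. Compound 3, `O=C(C1CCC2(CCC2)CC1)N1CC(c2nc(-c3cccc(Cl)c3)no2)C1`, differs from compound 2 by a group of 9 heavy atoms (9 carbon; one four-membered non-aromatic ring of carbon only, one six-membered non-aromatic ring of carbon only) in place of a group of 7 heavy atoms (5 carbon, 1 nitrogen, 1 fluorine; one six-membered non-aromatic ring with 1 hetero atom), on a carbonyl carbon. Compound 3 carries an all-carbon group on the carbonyl carbon, as compound 1 does, whereas compound 2 carries a ring with a nitrogen there. On this basis the number for compound 3 is expected to move toward the value of compound 1, a step of a 5.5-fold lower number from compound 2 to compound 3 (0.74 log units; beyond the scatter) that is expected to lie beyond the scatter. Compound 3 is therefore estimated at 180 nM, with a range from 50 nM to 600 nM.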

Compound 3, half-maximal effective concentration: 1100 nM
For compound 3 the middle estimate is 6.1-fold (0.79 log units) below the measured one; measured number above the stated range.
By their numbers in this assay, from the lowest: compound 1; then compounds 2 and 3 (each within the scatter of the next).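

In this assay, putting the all-carbon spiro group in place of 4-fluoropiperidin-1-yl on the carbonyl carbon gives a 1.1-fold higher number from compound 2 to compound 3 (0.05 log units; within the scatter) with the rest of the molecule unchanged. At this place, then, a carbon-only group and a ring with a nitrogen read alike, so the absence of that nitrogen does not by itself bring a compound close to compound 1 at 72 nM in this pair. Nothing at hand accounts for this result.

As far as these compounds go, compound 1 differs from compound 3 in more than one place, so it remains open how much of its lower number comes from its group on the carbonyl carbon and how much from the fluorine in place of chlorine on the aromatic ring. Also open, from the compounds shown here alone, is how a smaller group here, such as cyclobutyl or tert-butyl, would read.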